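Swapping the pyrazole aryl group: a trifluoromethylphenyl trial

The compounds below may be only part of what the source reports. "The series", "measured", "known", "first", "only" and "open" are said of these compounds alone.

Of the compounds shown here, three sharing one core have been tested in a functional assay on BJAB cells (Homo sapiens) for antiproliferative activity, with a stated time of 4 days; a higher number here means that more compound is needed for the effect, a lower number that less compound is needed. Compound 1 `COc1ccc(-c2c(C)nn(-c3nc(-c4ccc(Cl)c(Cl)c4)c(SC(C)C)s3)c2C(=O)O)cc1` gives 2100 nM. Compound 2 `Cc1nn(-c2nc(-c3ccc(Cl)c(Cl)c3)c(SC(C)C)s2)c(C(=O)O)c1-c1ccccc1` gives 3000 nM. Compound 3 `CCOc1ncccc1-c1c(C)nn(-c2nc(-c3ccc(Cl)c(Cl)c3)c(SC(C)C)s2)c1C(=O)O` gives 11000 nM, the highest number of the three; its nearest neighbour is compound 2, and a 3.7-fold higher number from compound 2 to compound 3 (0.56 log units; beyond the scatter), while a 5.2-fold higher number from compound 1 to compound 3 (0.72 log units; beyond the scatter). The step of a 1.4-fold higher number from compound 1 to compound 2 (0.15 log units; within the scatter) lies within the scatter.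

Compound 4 `Cc1nn(-c2nc(-c3ccc(Cl)c(Cl)c3)c(SC(C)C)s2)c(C(=O)O)c1-c1cccc(C(F)(F)F)c1` differs from compound 3 in one place: 3-(trifluoromethyl)phenyl in place of 2-ethoxypyridin-3-yl on an aromatic carbon. Among the measured compounds shown here, no measured step introduces a trifluoromethyl group, so the closest guide is the step between a plain carbon-only ring and the pyridine ring, a 3.7-fold higher number from compound 2 to compound 3 (0.56 log units; beyond the scatter), which in the reverse direction points toward a lower number for compound 4 than for compound 3. Compound 2 gives 3000 nM, and compound 4 is expected to sit near it, with a 3.1-fold lower number from compound 3 to compound 4 (0.50 log units; beyond the scatter). The estimate for compound 4 in this assay is therefore 3500 nM, within a range from 1200 nM to 10000 nM.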

Compound 4, half-maximal effective concentration: 22000 nM
Compound 4: middle estimate off by 6.3-fold (0.80 log units), on the low side; measured number outside the range, above it.
By their numbers in this assay, from the lowest: compounds 1 and 2 (each within the scatter of the next); then compounds 3 and 4 (each within the scatter of the next).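

In this assay, placing trifluoromethyl on the phenyl ring gives a 7.3-fold higher number from compound 2 to compound 4 (0.87 log units; beyond the scatter) and so moves the number beyond the scatter, whereas the earlier swap between phenyl and 4-methoxyphenyl did not. The widest gap so far also appears here, with a 10-fold higher number from compound 1 to compound 4 (1.02 log units; beyond the scatter) for the change from 4-methoxyphenyl to 3-(trifluoromethyl)phenyl, while a 2.0-fold higher number from compound 3 to compound 4 (0.30 log units; within the scatter) leaves this group and 2-ethoxypyridin-3-yl unresolved in this assay. No measurement shown here accounts for these differences.

The compounds shown cannot separate the effect of the trifluoromethyl group itself from the effect of where it sits on the ring. Also open, on these data alone, is how the number would respond to an amine or a nitrile on that phenyl ring.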